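A few compounds are considered here, and "the series" means these few. Any claim that something is new, unique, unknown or untested is made for them only; others in the source may bear on it.

Compound 2 `O=C(O)c1ccc2nc(N3CCC(OCc4c(-c5c(F)cccc5F)noc4C4CC4)CC3)sc2c1` gives the highest of the two numbers in an assay on HEK-293T cells for agonist activity at Bile acid receptor (Homo sapiens), read by a luciferase reporter, with a stated time of 24 h (on this read-out lower numbers stand for an effect already at smaller amounts and higher numbers for an effect only at larger amounts of compound), so far, where compound 2 gives 88 nM. Among the measured compounds shown here, its nearest neighbour, compound 1 `O=C(O)c1ccc2nc(N3CCC(OCc4c(-c5c(Cl)cccc5Cl)noc4C4CC4)CC3)sc2c1`, gives 9.5 nM in this assay, and the single measured step is a 9.3-fold higher number from compound 1 to compound 2 (0.97 log units; beyond the scatter), the only comparison available at this position. Compound 3 `O=C(O)c1ccc2nc(N3CCC(OCc4c(-c5ccccc5C(F)(F)F)noc4C4CC4)CC3)sc2c1` differs from compound 2 by 2-(trifluoromethyl)phenyl in place of 2,6-difluorophenyl on an aromatic carbon. For the measured compounds named here, the step from compound 1 to compound 2 bears on it only in that it shows the group on this aromatic carbon to matter, with a change of the substituent pattern moving the number well beyond the scatter; no measured step reaches a trifluoromethyl at this place. Going by the values given here, compound 3 is therefore expected to show a 2.9-fold lower number from compound 2 to compound 3 (0.47 log units; beyond the scatter) in this assay, with a wide range because the one step of a 9.3-fold higher number from compound 1 to compound 2 (0.97 log units; beyond the scatter) was large. The estimate for compound 3 in this assay is 30 nM, between 6 nM and 150 nM.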

Compound 3, half-maximal effective concentration in the Bile acid receptor assay: 70 nM
The estimate for compound 3 lay 2.3-fold (0.37 log units) below the measured number; the measured number falls inside the stated range.
By their numbers in the Bile acid receptor assay, from the lowest: compound 1; then compounds 3 and 2 (each within the scatter of the next).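

In the Bile acid receptor assay compound 2 gives 88 nM and compound 3 gives 70 nM, and the change to 2-(trifluoromethyl)phenyl gives a 1.3-fold lower number from compound 2 to compound 3 (0.10 log units; within the scatter), so at this place on the five-membered aromatic ring this group cannot be told apart from 2,6-difluorophenyl, although it differs in its substitution pattern and heavy-atom count. In the Bile acid receptor assay the 2,6-dichlorophenyl group stays apart from it, with a 7.4-fold higher number from compound 1 to compound 3 (0.87 log units; beyond the scatter), and among the three compounds compound 1 alone has the low number. In a physicochemical assay for solubility, in simulated intestinal fluid, at pH 6.8 (a lower number here means a less soluble compound, a higher number a more soluble compound), compound 2 gives 169000 nM and compound 3 gives 131000 nM, the same change gives a 1.3-fold lower number from compound 2 to compound 3 (0.11 log units; within the scatter), and no evidence at hand bears on these results.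

On these data alone, whether chlorine itself is what sets compound 1 apart remains open, and a 2-chlorophenyl or 2-chloro-6-fluorophenyl group at this place would test that. Also open, as far as these compounds go, is whether a 2-methoxyphenyl group would fall with compounds 2 and 3 or with compound 1.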